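Imidazoline ethers: pyrazole in place of pyrimidine

A few compounds are considered here, and "the series" means these few. Any claim that something is new, unique, unknown or untested is made for them only; others in the source may bear on it.

Measured compounds in a functional assay for activation of Alpha-1A adrenergic receptor (Homo sapiens), read by calcium flux; on this read-out lower numbers stand for an effect already at smaller amounts and higher numbers for an effect only at larger amounts of compound:
- compound 1, `CCN(CC)C(=O)c1ccccc1OCC1=NCCN1`, gives < 5020 nM, which is a limit of the assay and not a number
- compound 2, `Cc1cccc(-c2ccccc2OCC2=NCCN2)n1`, gives 126 nM
- compound 3, `c1ccc(-c2ccncn2)c(OCC2=NCCN2)c1`, gives < 100000 nM, again a limit and not a number

Compound 3 therefore has no number of its own; its result is one of two limits among the three values, as the limit of < 100000 nM in this assay, at which 1 of the 3 values shown sits, records, while compound 1 sits at the other limit, (the limit of < 5020 nM in this assay, at which 1 of the 3 values shown sits). Only compound 2 carries a real number in this assay. The next compound, compound 4, `c1ccc(-c2cc[nH]n2)c(OCC2=NCCN2)c1`, differs from compound 3 in one place: 1H-pyrazol-3-yl in place of pyrimidin-4-yl on an aromatic carbon. Within the data shown here, since compound 3 is a limit, no measured step is available to anchor this change, and the expectation rests largely on compound 2 as the only aryl partner with a number. With a ring of different size and a hydrogen-bond donor entering, the step from compound 3 to compound 4 is expected to be a step that the limit leaves unreadable from compound 3 to compound 4, but with wide uncertainty. Compound 4 is estimated at 600 nM in this assay, within a range from 60 nM to 6000 nM.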

Compound 4, half-maximal effective concentration: 5.01 nM
Compound 4: the middle estimate sits 120-fold (2.08 log units) above what was measured; measured number below the stated range.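

The result for compound 3 is a limit and not a number, so the change to compound 4 has no readable size: the limit of < 100000 nM in this assay, at which 1 of the 4 values shown sits.

The compounds shown leave open how large a shift in potency comes with 1H-pyrazol-3-yl in place of pyrimidin-4-yl.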